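Piperazine dithiocarbamate benzamides: swapping the pyridine attachment

The compounds below may be only part of what the source reports. "The series", "measured", "known", "first", "only" and "open" are said of these compounds alone.

Compound 1 `CN(Cc1cccnc1)C(=S)SCc1ccc(C(=O)Nc2ccccc2N)cc1`: 16.4%
Compound 2 `Nc1ccccc1NC(=O)c1ccc(CSC(=S)N2CCN(c3ccncc3)CC2)cc1`: 77%

Of the compounds shown here, two have been measured in a functional assay on HeLa cells (Homo sapiens) for antiproliferative activity, read by CCK-8 assay, with a stated time of 72 h, tested at 2 uM; a lower number here means a weaker effect, a higher number a stronger effect of the compound at the concentration tested. Compound 1 gives 16.4%, while compound 2 gives 77%, the higher of the two numbers by a margin beyond the scatter. For the measured compounds named here, no step between compounds that differ in a single place is available among the measured pair, so the record gives no direct guide for the next change.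

Compound 3 `Nc1ccccc1NC(=O)c1ccc(CSC(=S)N2CCN(Cc3cccnc3)CC2)cc1` keeps the core of compound 2 and differs from it by one change: (pyridin-3-yl)methyl in place of pyridin-4-yl on an amine nitrogen in a ring. Going by the values given here, compound 1, the only other compound with a (pyridin-3-yl)methyl group, gives 16.4%, but it differs from compound 3 in more than one place, so its number serves only as a loose reference. Compound 3 is expected to land somewhat below compound 2, with a step of a number 27 percentage points lower from compound 2 to compound 3 (beyond the scatter) in this assay. The estimate for compound 3 is 50%, with a range from 20% to 78%.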

Compound 3, a percentage reported as inhibition, at one concentration (the size of the read-out at that concentration, not a potency): 69.7%
Estimate against measurement, compound 3: 19.7 percentage points below; measured number inside the range.
By their numbers in this assay, from the lowest: compound 1; then compounds 3 and 2 (each within the scatter of the next).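

In this assay, for the compounds shown here, the first step between compounds that differ in one place is a number 7.3 percentage points lower from compound 2 to compound 3 (within the scatter) and so, on this amine nitrogen in a ring, (pyridin-3-yl)methyl and pyridin-4-yl cannot be told apart by this read-out. The position therefore accepts a change in how the pyridine ring is attached, and the shift from a directly attached ring to a methyl-linked one leaves the inhibition within the usual scatter. No measurement at hand speaks to the reason for this result.

The compounds shown leave open whether a plain benzyl group, a 2-(pyridin-3-yl)ethyl chain or a simple methyl on the same nitrogen would give a similar read-out. They also do not show how a change elsewhere on the shared core would act.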